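The source may report more compounds than this note shows. Statements on the series, on what has been measured and on what is new or still open speak of the compounds shown alone.

In an assay on isolated protein for inhibition of aldehyde dehydrogenase 1A1 (Homo sapiens), read by spectrophotometry, tested at 10 uM (a higher number here means more inhibition at the concentration tested (going by the name of the read-out), a lower number less inhibition), compound 1 `Cc1cccc(Cn2c(CN3CCN(C(=O)c4ccc([N+](=O)[O-])cc4)CC3)nc3ccccc32)c1` gives 24.3%, the lowest of the three numbers recorded. Compound 2 `COc1ccc(C(=O)N2CCN(Cc3nc4ccccc4n3Cc3cccc(C)c3)CC2)cc1` gives 55.5% in this assay, and compound 3 `Cc1cccc(Cn2c(CN3CCN(C(=O)c4cccs4)CC3)nc3ccccc32)c1` gives 60.8%. Both measured steps away from the nitro compound move the read-out upward by a large margin: a number 31.2 percentage points higher from compound 1 to compound 2 (beyond the scatter), and a number 36.5 percentage points higher from compound 1 to compound 3 (beyond the scatter). The remaining step is a number 5.3 percentage points higher from compound 2 to compound 3 (within the scatter), which lies within the scatter.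

Compound 4 `Cc1cccc(Cn2c(CN3CCN(C(=O)c4ccc(C(F)(F)F)cc4)CC3)nc3ccccc32)c1` differs from compound 1 by trifluoromethyl in place of nitro on an aromatic carbon. Among the measured compounds shown here, no measured step exchanges nitro for trifluoromethyl, so the only guidance comes from the two exchanges of the nitro-bearing group already in hand, both of which raised inhibition well beyond the scatter. On that basis the expected step is a number 20.7 percentage points higher from compound 1 to compound 4 (beyond the scatter), a more modest rise than either measured step, since compound 4 keeps the same six-membered aromatic ring and changes only its substituent. Compound 4 is therefore estimated at 45%, with a plausible range from 22% to 68%.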

Compound 4, a percentage reported as inhibition, at one concentration (the size of the read-out at that concentration, not a potency): 22.9%
For compound 4 the middle estimate is 22.1 percentage points above the measured one; the range from low to high includes it.
By their numbers in this assay, from the lowest: compounds 4 and 1 (each within the scatter of the next); then compounds 2 and 3 (each within the scatter of the next).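

Replacing nitro with trifluoromethyl on the aromatic carbon para to a large group leaves the read-out in this assay essentially unchanged, a number 1.4 percentage points lower from compound 1 to compound 4 (within the scatter), so the two groups cannot be told apart at this position. Methoxy at the same place stands well clear of trifluoromethyl, a number 32.6 percentage points lower from compound 2 to compound 4 (beyond the scatter), and the exchange of the whole aryl group for thiophen-2-yl gives a similar gap, a number 37.9 percentage points lower from compound 3 to compound 4 (beyond the scatter), so the rise seen earlier depends on what replaces nitro and does not follow from its loss alone. Nothing available here accounts for the separation between these groups.

As far as these compounds go, it remains open whether an amine, a hydroxyl group or a nitrile at this place would sit with methoxy or with nitro and trifluoromethyl. From the compounds shown here alone, it is also open whether these differences would persist if the methyl group on the shared core gave way to an ethyl chain.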